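The source may report more compounds than this note shows. Statements on the series, on what has been measured and on what is new or still open speak of the compounds shown alone.

For the measured compounds named here, in a functional assay on COR-L23 cells (Homo sapiens) for antiproliferative activity, read by CellTiter-Glo, with a stated time of 72 h (a higher number here means a weaker inhibitor, a lower number a stronger inhibitor), compound 3 (`C[C@H](NC(=O)[C@@H]1CCCN1C)c1ccc(NC(=O)N2CC(c3ccc(N)nc3)C2)cc1`) gives 41 nM and holds the lowest number so far, with compound 2 (`C[C@H](NC(=O)C1CCOCC1)c1ccc(NC(=O)N2CC(c3ccc(N)nc3)C2)cc1`) at 110 nM and compound 1 (`C[C@H](NC(=O)c1ncccn1)c1ccc(NC(=O)N2CC(c3ccc(N)nc3)C2)cc1`) at 160 nM in the same read-out. Compound 4 (`C[C@H](NC(=O)[C@@H]1CCCN1C)c1ccc(NC(=O)N2CC(c3cncc(N)c3)C2)cc1`) has the same atoms as compound 3, joined differently: 5-aminopyridin-3-yl in place of 6-aminopyridin-3-yl on a saturated ring carbon.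

The measured steps all replace the group on a carbonyl carbon: a 1.5-fold lower number from compound 1 to compound 2 (0.16 log units; within the scatter) lies within the scatter, while a 3.9-fold lower number from compound 1 to compound 3 (0.59 log units; beyond the scatter) and a 2.7-fold lower number from compound 2 to compound 3 (0.43 log units; beyond the scatter) are modest and beyond it. Going by the values given here, none of them touches the 6-aminopyridin-3-yl group, so the data offer no direct precedent for this change and no measured direction. They serve only as a guide to size. A modest step is therefore expected, on the scale of a 2.7-fold lower number from compound 2 to compound 3 (0.43 log units; beyond the scatter) and no larger than a 3.9-fold lower number from compound 1 to compound 3 (0.59 log units; beyond the scatter) as a central guess. A higher number is the likelier direction, as compound 3 at 41 nM already stands lowest of the three. In this assay the expected step is a 2.2-fold higher number from compound 3 to compound 4 (0.34 log units; beyond the scatter) and its direction remains the least certain part. For compound 4 the expected value is 90 nM (estimated range 20 nM to 400 nM).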

Compound 4, half-maximal inhibitory concentration: 200 nM
Compound 4: the middle estimate sits 2.2-fold (0.35 log units) below what was measured, within the range that was stated.
By their numbers in this assay, from the lowest: compound 3; then compounds 2, 1 and 4 (each within the scatter of the next).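

Moving from 6-aminopyridin-3-yl to 5-aminopyridin-3-yl on the saturated ring carbon of the four-membered ring gives a 4.9-fold higher number from compound 3 to compound 4 (0.69 log units; beyond the scatter) in this assay. For the compounds shown here, this is the first reading at this place, since the earlier steps all changed the group on the carbonyl carbon, and it shows that the number responds here even though the entering and leaving groups have the same atoms and the same counts of donors and acceptors. With 1-methylpyrrolidin-2-yl on the carbonyl carbon, the direction favours the 6-aminopyridin-3-yl group, but no information is available that explains this step.

On these data alone, whether the same direction and size hold with oxan-4-yl or pyrimidin-2-yl on the carbonyl carbon remains open, as this change is read against a single partner group. Also open, as far as these compounds go, is how much of the number depends on the amine itself, a question that a pyridin-3-yl group without the amine, or one carrying a methylamino group or a hydroxyl group in its place, would address.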